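Piperidinylethyl urea in the benzothiazole series

A few compounds are considered here, and "the series" means these few. Any claim that something is new, unique, unknown or untested is made for them only; others in the source may bear on it.

Compound 1 `COc1ncc(-c2ccc3nc(NC(=O)NCCN(C)C)sc3c2)cc1NS(=O)(=O)c1ccc(F)cc1` and compound 2 `COc1ncc(-c2ccc3nc(NC(=O)NC4CC4)sc3c2)cc1NS(=O)(=O)c1ccc(F)cc1` differ only by cyclopropyl in place of 2-(dimethylamino)ethyl on an amide-type nitrogen. In a functional assay on HCT-116 cells (Homo sapiens) for antiproliferative activity, read by MTT assay, with a stated time of 72 h (on this read-out higher numbers stand for weaker inhibition and lower numbers for stronger inhibition), compound 1 gives 240 nM, and compound 2 gives 470 nM; the step of a 2.0-fold higher number from compound 1 to compound 2 (0.29 log units; within the scatter) lies within the scatter, so compound 2 simply stands at one end of the two values. Compound 3 `COc1ncc(-c2ccc3nc(NC(=O)NCCN4CCCCC4)sc3c2)cc1NS(=O)(=O)c1ccc(F)cc1` carries the change (2-(piperidin-1-yl)ethyl in place of cyclopropyl on an amide-type nitrogen). Among the measured compounds shown here, only that one step bears on it. Compound 3 is therefore expected to give 250 nM, within 100 nM to 600 nM, because compound 1 gives 240 nM with its 2-(dimethylamino)ethyl group. The expected step of a 1.9-fold lower number from compound 2 to compound 3 (0.27 log units; within the scatter) is estimated to stay within the scatter.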

Compound 3, half-maximal inhibitory concentration: 610 nM
The estimate for compound 3 lay 2.4-fold (0.39 log units) below the measured number, and the stated range ends below it.
By their numbers in this assay, from the lowest: compounds 1, 2 and 3 (each within the scatter of the next, the first and the last beyond it).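

In this assay piperidin-1-yl in place of dimethylamino on the chain gives a 2.5-fold higher number from compound 1 to compound 3 (0.41 log units; beyond the scatter) and so, though the step is modest, the end group of this chain does register. Set against cyclopropyl, 2-(piperidin-1-yl)ethyl gives a 1.3-fold higher number from compound 2 to compound 3 (0.11 log units; within the scatter) and cannot be told apart from it at this amide-type nitrogen. No evidence at hand accounts for either step. From the compounds shown here alone, whether a 2-(morpholin-4-yl)ethyl group or a longer chain ending in dimethylamino would read closer to compound 1 or to compound 3 stays open.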